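Swapping phenyl for thiophene on a shared core

The compounds below may be only part of what the source reports. "The series", "measured", "known", "first", "only" and "open" are said of these compounds alone.

Measured so far: compound 1 `Nc1c(C(=O)NC2CCCC2)oc2nc(-c3ccccc3)cc(C(F)(F)F)c12` gives 32400 nM in a functional assay on HepG2 cells (Homo sapiens) for antiproliferative activity, read by MTT assay; on this read-out lower numbers stand for stronger inhibition and higher numbers for weaker inhibition; compound 2 `CCNC(=O)c1oc2nc(-c3cccs3)cc(C(F)(F)F)c2c1N` gives 12100 nM; compound 3 `CCCNC(=O)c1oc2nc(-c3ccccc3)cc(C(F)(F)F)c2c1N` gives 37400 nM.

Compound 3 has the highest number of the three. Its gap to compound 1, a 1.2-fold higher number from compound 1 to compound 3 (0.06 log units; within the scatter), is within the usual scatter, so the two cannot be told apart; the value of compound 2 lies clearly below both. Going by the values given here, the only single step measured, a 1.2-fold higher number from compound 1 to compound 3 (0.06 log units; within the scatter), concerns the amide side and was small.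

Compound 4 `CCCNC(=O)c1oc2nc(-c3cccs3)cc(C(F)(F)F)c2c1N` differs from compound 3 by thiophen-2-yl in place of phenyl on an aromatic carbon. Among the compounds with values here, no measured pair isolates this change; compound 2 carries the same thiophene but also a shorter amide chain. Since the amide change barely mattered, much of the difference between compound 2 and compound 3 may come from the ring swap. Compound 4 is therefore expected at 15000 nM, range 6000 nM to 40000 nM, a step of a 2.5-fold lower number from compound 3 to compound 4 (0.40 log units; beyond the scatter) that is expected.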

Compound 4, half-maximal inhibitory concentration: 17200 nM
Compound 4: middle estimate off by 1.1-fold (0.06 log units), on the low side, and the stated range covers the measured number.
By their numbers in this assay, from the lowest: compounds 2, 4, 1 and 3 (each within the scatter of the next, the first and the last beyond it).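

Thiophen-2-yl in place of phenyl on this aromatic carbon, next to the ring nitrogen, now has a step of its own in this assay, with the propyl amide unchanged (a 2.2-fold lower number from compound 3 to compound 4 (0.34 log units; beyond the scatter)). With the thiophene present, methyl in place of hydrogen on the amide chain has no readable effect (a 1.4-fold higher number from compound 2 to compound 4 (0.15 log units; within the scatter)). Nothing measured here gives a reason for the ring swap's step. Still open, going by these compounds, is how other rings on this carbon, such as furan or pyridine, would compare, and what an amine or a carboxylic acid on the amide chain would do.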